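Exchanging One Aryl Group at a Shared Carbon

The source may report more compounds than this note shows. Statements on the series, on what has been measured and on what is new or still open speak of the compounds shown alone.

Three analogues share one core and differ only in the aryl group on a saturated chain carbon bound to an aromatic carbon and an oxygen on a saturated carbon. In a functional assay on MIA PaCa-2 cells (Homo sapiens) for inhibition, read by MTT assay, with a stated time of 48 h, tested at 10 uM (on this read-out lower numbers stand for less inhibition of growth and higher numbers for more inhibition of growth at the one concentration tested), compound 1 `Cc1oc2c([C@H]3CCN(C)C[C@H]3O)c(O)cc(O)c2c(=O)c1C(O)c1cccc(Cl)c1` gives 2%, compound 2 `Cc1oc2c([C@H]3CCN(C)C[C@H]3O)c(O)cc(O)c2c(=O)c1C(O)c1ccc(F)c(Br)c1` gives 9% and compound 3 `Cc1oc2c([C@H]3CCN(C)C[C@H]3O)c(O)cc(O)c2c(=O)c1C(O)c1c(F)cccc1Cl` gives 41%. Compound 3 stands highest, while the other two do not separate, with a number 7 percentage points higher from compound 1 to compound 2 (within the scatter). The lead of compound 3 is large on both sides, with a number 39 percentage points higher from compound 1 to compound 3 (beyond the scatter) and a number 32 percentage points higher from compound 2 to compound 3 (beyond the scatter).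

Compound 4 `CCOc1ccc(Br)c(C(O)c2c(C)oc3c([C@H]4CCN(C)C[C@H]4O)c(O)cc(O)c3c2=O)c1` has not yet been measured. It carries 2-bromo-5-ethoxyphenyl in place of 2-chloro-6-fluorophenyl at the same carbon: 2-bromo-5-ethoxyphenyl in place of 2-chloro-6-fluorophenyl on a saturated chain carbon bound to an aromatic carbon and an oxygen on a saturated carbon. Within the data shown here, no measured compound has an ethoxy group, so no step speaks to this exchange directly. All three steps do change the aryl group at this carbon, however, and the two large ones show that only compound 3 has reached a clearly higher number. A fall in this assay is therefore expected, probably beyond the scatter but smaller than those two steps, though the evidence is thin. The expected change is a number 21 percentage points lower from compound 3 to compound 4 (beyond the scatter). For compound 4 the estimated value is 20%, with an expected range of 3% to 45%.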

Compound 4, percent growth inhibition at one concentration: 4%
Estimate against measurement, compound 4: 16 percentage points above; the measured number falls inside the stated range.
By their numbers in this assay, from the lowest: compounds 1, 4 and 2 (each within the scatter of the next); then compound 3.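

In this assay the step of a number 37 percentage points lower from compound 3 to compound 4 (beyond the scatter) shows that the high number of compound 3 does not carry over to a larger aryl group that also holds a halogen, and among the four aryl groups at this carbon, only 2-chloro-6-fluorophenyl now stands apart. Compound 4 does not separate from the two low compounds, with a number 5 percentage points lower from compound 2 to compound 4 (within the scatter) and a number 2 percentage points higher from compound 1 to compound 4 (within the scatter) both within the scatter, so 3-chlorophenyl, 3-bromo-4-fluorophenyl and 2-bromo-5-ethoxyphenyl cannot be ordered in this assay, even though the last brings in an ethoxy group that neither of the other two carries. Nothing given here bears on why this exchange lowers the number.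

The bromine and the ethoxy group enter together in a single step, so the compounds shown leave open which of the two goes with the lower number, and whether a 2-bromophenyl group alone would stay near compound 3. They also leave open whether 2,6-dichlorophenyl or 2,6-difluorophenyl at this carbon would hold the number of compound 3 or fall to the level of the other three.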